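Amide series: from compound 2 to compound 4

The source may report more compounds than this note shows. Statements on the series, on what has been measured and on what is new or still open speak of the compounds shown alone.

In a physicochemical assay for solubility (on this read-out higher numbers stand for higher solubility and lower numbers for lower solubility), compound 1 `O=C(c1ccccc1)N1CCC(NS(=O)(=O)c2cc(S(=O)(=O)c3ccccc3)ccc2C(F)(F)F)CC1` gives 12500 nM, compound 2 `CN(C)c1ccc(C(=O)N2CCC(NS(=O)(=O)c3cc(S(=O)(=O)c4ccccc4)ccc3C(F)(F)F)CC2)cc1` gives 50000 nM and compound 3 `O=C(O)c1cccc(S(=O)(=O)N2CCC(NS(=O)(=O)c3cc(S(=O)(=O)c4ccccc4)ccc3C(F)(F)F)CC2)c1` gives 12500 nM. Compound 2 holds the highest number of the three, clear of the scatter against both others.

Compound 4 `CC(C)(C)OC(=O)N1CCC[C@H]1C(=O)N1CCC(NS(=O)(=O)c2cc(S(=O)(=O)c3ccccc3)ccc2C(F)(F)F)CC1` has not yet been measured. It differs from compound 2 by one change on a carbonyl carbon: 1-(tert-butoxycarbonyl)pyrrolidin-2-yl in place of 4-(dimethylamino)phenyl on a carbonyl carbon. The dimethylamino group leaves with the aromatic ring that carries it.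

For the measured compounds named here, three measured steps bear on this. Adding dimethylamino in place of hydrogen on an aromatic carbon gives a 4.0-fold higher number from compound 1 to compound 2 (0.60 log units; beyond the scatter), and replacing the whole acyl group gives a 4.0-fold lower number from compound 2 to compound 3 (0.60 log units; beyond the scatter). Between the two compounds without dimethylamino, the step is no change at the digits printed from compound 1 to compound 3 (within the scatter), within the scatter. Among these three compounds, only the one carrying dimethylamino stands higher, and none goes against this. Going by the values given here, no measured compound has a non-aromatic group on this carbonyl, so the range stays wide.

A modest step down is therefore expected, close in size to the measured ones, and the expected step is a 3.6-fold lower number from compound 2 to compound 4 (0.55 log units; beyond the scatter). The estimated value for compound 4 is 14000 nM, with an expected range of 5000 nM to 40000 nM.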

Compound 4, solubility: 25000 nM
The estimate for compound 4 lay 1.8-fold (0.25 log units) below the measured number; measured number inside the range.
By their numbers in this assay, from the lowest: compounds 1, 3, 4 and 2 (each within the scatter of the next, the first and the last beyond it).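

In this assay, for the compounds shown here, compound 4 is the only compound here with a non-aromatic group on this carbonyl carbon, and placing 1-(tert-butoxycarbonyl)pyrrolidin-2-yl there instead of 4-(dimethylamino)phenyl gives a 2.0-fold lower number from compound 2 to compound 4 (0.30 log units; within the scatter). In place of phenyl on the same carbon, the same group gives a 2.0-fold higher number from compound 1 to compound 4 (0.30 log units; within the scatter), so compound 4 cannot be separated from either neighbour, even though those two stand apart by a 4.0-fold higher number from compound 1 to compound 2 (0.60 log units; beyond the scatter); the position therefore accepts a non-aromatic ring without a step beyond the scatter in either comparison, and compound 2 is no longer clearly apart from every compound lacking dimethylamino. No measurement shown accounts for this result.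

Still open, from the compounds shown here alone, is whether the pyrrolidine ring with a free secondary amine in place of the tert-butoxycarbonyl carbamate, or with a carboxylic acid on the ring, would give a step beyond the scatter from compound 4. Also open, going by these compounds, is whether the defined stereocentre of compound 4 matters, which would take the opposite configuration at that carbon to settle, and whether an open-chain amine on this carbonyl carbon would read like the ring.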